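The source may hold more compounds than are shown below. What is called first, only, known or untested is meant among the compounds shown, and "the series" means these compounds.

Working notes on the series.

The shared core is an arylsulfonyl piperidine; the compounds differ in the group on a saturated ring carbon of that piperidine. Compound 1 `Cc1cc(C)c(S(=O)(=O)N2CCC(C(=O)N3CCC(C)CC3)CC2)c(C)c1` carries a (4-methylpiperidin-1-yl)carbonyl there. In a functional assay on DLD-1 cells (Homo sapiens) for antiproliferative activity, read by CellTiter-Glo, with a stated time of 72 h (a lower number here means a stronger inhibitor, a higher number a weaker inhibitor), compound 1 reaches only a limit, > 5000 nM, which is the limit of > 5000 nM in this assay, at which 1 of the 3 values shown sits. Compound 2 `Cc1cc(C)c(S(=O)(=O)N2CCC(N3CCN(C)CC3)CC2)c(C)c1` carries 4-methylpiperazin-1-yl, and in this assay compound 2 gives 1100 nM, an at least 4.5-fold lower number from compound 1 to compound 2 (0.65 log units; beyond the scatter). Compound 3 `Cc1cc(C)c(S(=O)(=O)N2CCC(N3CCC(C)OC3)CC2)c(C)c1` carries the methyl-substituted morpholine ring, and in this assay compound 3 gives 92 nM; this is an at least 54-fold lower number from compound 1 to compound 3 (1.73 log units; beyond the scatter) and a 12-fold lower number from compound 2 to compound 3 (1.08 log units; beyond the scatter). Compound 3 thus stands at the lowest number of the two measured, with compound 2 the nearest.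

Compound 4 `Cc1cc(C)c(S(=O)(=O)N2CCC(N3CCCCCC3)CC2)c(C)c1` is not yet measured. Relative to compound 3 the change is a group of 7 heavy atoms (6 carbon, 1 nitrogen; one seven-membered non-aromatic ring with 1 hetero atom) in place of a group of 7 heavy atoms (5 carbon, 1 nitrogen, 1 oxygen; one six-membered non-aromatic ring with 2 hetero atoms), on a saturated ring carbon. The step that bears on it most directly is the ring swap on the same carbon from compound 2 to compound 3, which was large; the steps from compound 1 were at least modest and at least large but start from a limit. A second swap of the saturated amine ring is therefore expected to move the number beyond the scatter, and with the oxygen gone the direction is taken as a move back toward compound 2, with wide uncertainty. Compound 4 is expected to give 350 nM in this assay, in the range 90 nM to 1500 nM, which would be a 3.8-fold higher number from compound 3 to compound 4 (0.58 log units; beyond the scatter).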

Compound 4, half-maximal inhibitory concentration: 5.3 nM
Beside the measured number, compound 4's estimate is 66-fold (1.82 log units) above it; the whole stated range lies above it.
By their numbers in this assay, from the lowest: compound 4; then compound 3; then compound 2. At a limit, above all of these: compound 1.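

Compound 4 shows that a second ring hetero atom, present in the rings of compound 2 and compound 3, is not needed for a low number at this saturated ring carbon in this assay: azepan-1-yl, with nitrogen as its only ring hetero atom, gives a 17-fold lower number from compound 3 to compound 4 (1.24 log units; beyond the scatter). Within the data shown here, the same group gives a 210-fold lower number from compound 2 to compound 4 (2.32 log units; beyond the scatter), making compound 4 the lowest of the series so far and showing that this position still has a wide range to give after the gain seen with compound 3. The largest listed gap, an at least 940-fold lower number from compound 1 to compound 4 (2.97 log units; beyond the scatter), is a bound only, since compound 1 stands at a limit: the limit of > 5000 nM in this assay, at which 1 of the 4 values shown sits.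

The step to azepan-1-yl changes ring size and removes the ring oxygen together, so the compounds shown do not separate these two changes; piperidin-1-yl, the six-membered ring with nitrogen alone, would bear on that directly. Also open, going by these compounds, is whether a larger eight-membered amine ring, or a methyl or hydroxyl group on the azepane ring, would hold the number of compound 4.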